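Two Inverted Stereocentres at the Low End of Stability

This account rests on a few compounds, and the source may have more. Where it says the series, first, only, none or still open, it means among the compounds named here.

In an ADME assay on microsomes from liver (Rattus norvegicus) for metabolic stability, using NADPH, with a stated time of 10 min (on this read-out higher numbers stand for a more stable compound and lower numbers for a less stable compound), compound 1 `CN(C[C@H]1Cc2c(cccc2N2CCC(N)CC2)CN1)[C@H]1CCCc2cccnc21` gives 38.4% and compound 2 `CN(C[C@H]1Cc2c(cccc2N2C[C@H]3CNC[C@H]3C2)CN1)[C@H]1CCCc2cccnc21` gives 38.1%, and the step between them is a number 0.3 percentage points lower from compound 1 to compound 2 (within the scatter). Compound 3 `CN1CC[C@H]2CN(c3cccc4c3C[C@H](CN(C)[C@H]3CCCc5cccnc53)NC4)C[C@H]21` stands lowest of the three at 1.78%, with steps of a number 36.6 percentage points lower from compound 1 to compound 3 (beyond the scatter) and a number 36.3 percentage points lower from compound 2 to compound 3 (beyond the scatter). Compound 4 `CN(C[C@H]1Cc2c(cccc2N2C[C@H]3CCN(C)[C@H]3C2)CN1)[C@H]1CCCc2cccnc21` has not yet been measured. Its relation to compound 3 is this: the two compounds have the same atoms and bonds and differ only in configuration as drawn: 2 of 4 stereo elements differ; a stereocentre at a saturated ring carbon is drawn S in compound 3 and R in compound 4; a stereocentre at a saturated ring carbon is drawn S in compound 3 and R in compound 4. Within the data shown here, no measured step isolates a change of configuration, so the evidence is indirect. The two steps reaching compound 3 are both large and show that the group on the aromatic carbon can move this read-out strongly, but each of them also changes atoms and bonds, whereas compound 4 keeps those of compound 3. The estimate therefore starts from compound 3 at 1.78% and leaves room for a larger rise. The estimated step is a number 4.2 percentage points higher from compound 3 to compound 4 (within the scatter), so no change beyond the scatter is expected. For compound 4 the expected value is 6%, with an estimated range from 1% to 25%.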

Compound 4, percent of the compound remaining: 11.2%
Beside the measured number, compound 4's estimate is 5.2 percentage points below it; measured number inside the range.
By their numbers in this assay, from the lowest: compounds 3 and 4 (each within the scatter of the next); then compounds 2 and 1 (each within the scatter of the next).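

In this assay, among these compounds, the inversion of the two ring stereocentres gives the first reading of configuration alone at this position, and it amounts to a number 9.4 percentage points higher from compound 3 to compound 4 (within the scatter). This reading is free of any change in atoms or bonds, which every earlier step carried: the fact that compounds 3 and 4 differ only in the configuration as drawn. The group of 9 heavy atoms also stays clearly apart from the other two groups in the second configuration, with a number 26.9 percentage points lower from compound 2 to compound 4 (beyond the scatter) and a number 27.2 percentage points lower from compound 1 to compound 4 (beyond the scatter), so the low standing seen for compound 3 is not confined to a single drawn configuration.

From the compounds shown here alone, both stereocentres change together here, and the contribution of each alone stays open. Also open, going by these compounds, is how this read-out would respond to a carboxylic acid or a hydroxyl group on the group of 9 heavy atoms.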